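The source may hold more compounds than are shown below. What is called first, only, known or untested is meant among the compounds shown, and "the series" means these compounds.

Compound 2 `COC(CSc1nc(-c2ccccc2)c(-c2ccccc2)[nH]1)OC` is one of two compounds tested in an assay on microsomes from liver for inhibition of sterol O-acyltransferase 1 (Rattus norvegicus); on this read-out higher numbers stand for weaker inhibition and lower numbers for stronger inhibition; in this assay compound 2 gives 580 nM, the lowest of the two numbers, while compound 1 `O=C1CC(O)CC(CSc2nc(-c3ccccc3)c(-c3ccccc3)[nH]2)O1` gives 910 nM, and the step of a 1.6-fold lower number from compound 1 to compound 2 (0.20 log units; within the scatter) lies within the scatter, so neither stands apart from the other. Compound 3 `c1ccc(-c2nc(SCC3CCCCC3)[nH]c2-c2ccccc2)cc1` has not yet been measured. It differs from compound 2 by the change (cyclohexyl in place of dimethoxymethyl on a saturated chain carbon bound to a sulfur), a swap at the same place where compound 1 and compound 2 already differ. That earlier step, a 1.6-fold lower number from compound 1 to compound 2 (0.20 log units; within the scatter), is the only measured one that bears on the new change, and it was small. On that basis compound 3 is expected to stay close to compound 2, with a step of a 1.2-fold lower number from compound 2 to compound 3 (0.06 log units; within the scatter) that does not clearly go beyond the scatter. Compound 3 is therefore estimated to give 500 nM in this assay, with a likely range from 150 nM to 2000 nM.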

Compound 3, half-maximal inhibitory concentration: 100 nM
For compound 3 the middle estimate is 5.0-fold (0.70 log units) above the measured one; the whole stated range lies above it.
By their numbers in this assay, from the lowest: compound 3; then compounds 2 and 1 (each within the scatter of the next).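

The position on the saturated chain carbon bound to a sulfur now proves sensitive to the group placed there. In this assay, cyclohexyl in place of dimethoxymethyl gives a 5.8-fold lower number from compound 2 to compound 3 (0.76 log units; beyond the scatter) and the same cyclohexyl in place of the larger oxygen-containing ring group gives a 9.1-fold lower number from compound 1 to compound 3 (0.96 log units; beyond the scatter), whereas compound 1 and compound 2 alone showed only a step within the scatter. Nothing measured here accounts for these steps.

The three compounds do not show whether the lower number goes with the carbon-only ring itself or simply with a group free of oxygen, and a straight hexyl chain or a phenyl ring at this place would help separate the two. From the compounds shown here alone, how an amine or a carboxylic acid would fare here also remains open.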